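Aryl exchange on the double-bonded chain and cytotoxicity

The source may hold more compounds than are shown below. What is called first, only, known or untested is meant among the compounds shown, and "the series" means these compounds.

Compound 1 `COc1cccc(COc2ccc3cc(C(=O)/C=C/c4ccc(C)cc4)c(=O)oc3c2)c1` in a functional assay on K562 cells (Homo sapiens) for cytotoxicity, read by MTT assay, with a stated time of 72 h (a higher number here means a weaker inhibitor, a lower number a stronger inhibitor), gives > 50000 nM, which is a limit of the assay rather than a number.
Compound 2 `COc1cccc(COc2ccc3cc(C(=O)/C=C/c4ccccc4)c(=O)oc3c2)c1` in this assay gives > 100000 nM, again a limit of the assay.
Compound 3 `COc1cccc(COc2ccc3cc(C(=O)/C=C/c4c(Cl)cccc4Cl)c(=O)oc3c2)c1` in this assay gives 15600 nM.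

Going by the values given here, compound 3 thus carries the only real number among the three measured compounds; the other two sit at limits, the limit of > 100000 nM in this assay, at which 1 of the 3 values shown sits, and (the limit of > 50000 nM in this assay, at which 1 of the 3 values shown sits). The step that the two limits leave unreadable from compound 1 to compound 2 is therefore unreadable, since both ends are limits. The two steps that end at compound 3 are readable at their lower bound: an at least 3.2-fold lower number from compound 1 to compound 3 (0.50 log units; beyond the scatter) and an at least 6.4-fold lower number from compound 2 to compound 3 (0.80 log units; beyond the scatter).

Compound 4 `COc1cccc(COc2ccc3cc(C(=O)/C=C/c4cc(OC)ccc4OC)c(=O)oc3c2)c1` differs from compound 3 in one place: 2,5-dimethoxyphenyl in place of 2,6-dichlorophenyl on a double-bonded chain carbon bound to a double-bonded chain carbon. Among the compounds with values here, no measured compound carries a 2,5-dimethoxyphenyl at that position, so the step can only be judged by the two steps into compound 3, in which moving away from an aryl group without the 2,6-dichloro pattern gave a lower number. Leaving the 2,6-dichlorophenyl again is expected to reverse that, and a higher number is estimated for compound 4, roughly a 2.6-fold higher number from compound 3 to compound 4 (0.41 log units; beyond the scatter). Compound 4 is expected to give about 40000 nM, with a range of 12000 nM to 120000 nM, and a real chance that only a limit is reported.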

Compound 4, half-maximal inhibitory concentration: > 100000 nM
Compound 4 gave a limit, no number; the forecaster's own chance of this, stated with the estimate: 40%; at least 2.5-fold (0.39 log units) between middle value and limit.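

At this position, the change to 2,5-dimethoxyphenyl gives an at least 6.4-fold higher number from compound 3 to compound 4 (0.80 log units; beyond the scatter) in this assay, so the number seen for compound 3 does not survive this exchange of aryl group. The earlier compounds set the 2,6-dichlorophenyl only against phenyl and 4-methylphenyl, whereas this result shows that a phenyl ring bearing two groups is not enough in itself, since among the four compounds shown only the 2,6-dichlorophenyl of compound 3 gives a real number. Compound 4 stands at a limit, not a number, and the steps to it from compound 1 and compound 2 cannot be read, as both ends of each are limits: the limit of > 100000 nM in this assay, at which 2 of the 4 values shown sit.

Going by these compounds, whether the chlorine atoms themselves go with the number of compound 3 stays open, and a difluorophenyl or a dibromophenyl on this double-bonded chain carbon would bear on that question. A phenyl ring carrying an amine or a carboxylic acid at this place would further test whether anything other than a chlorine-bearing ring can reach a real number in this assay.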